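The source may hold more compounds than are shown below. What is called first, only, known or untested is meant among the compounds shown, and "the series" means these compounds.

Compound 3, `CCOC(=O)Cn1cc(CNCCN2CCN(C)CC2)c(-c2ccccc2C)n1`, is examined for cell toxicity in an ADME assay on Huh-7 cells (Homo sapiens) for cytotoxicity; on this read-out higher numbers stand for lower toxicity in this test and lower numbers for higher toxicity in this test. In this assay compound 3 reaches only the assay's limit, > 20000 nM, not a measured number. Two related compounds stand beside it. Compound 1, `Cc1ccccc1CNc1nn(-c2ccc(F)cc2F)cc1CNCCN1CCN(C)CC1`, also gives only a limit in this assay, > 20000 nM. Compound 2, `Cc1ccc(-c2nn(-c3ccc(F)cc3F)cc2CNCCN2CCN(C)CC2)cc1`, likewise gives only a limit, > 20000 nM. The step that the two limits leave unreadable from compound 1 to compound 2 is left unreadable by these two limits. All three values sit at the limit of > 20000 nM in this assay, at which 3 of the 3 values shown sit. Compound 4, `Cc1ccccc1-c1nn(-c2ccc(F)cc2F)cc1CNCCN1CCN(C)CC1`, differs from compound 3 by 2,4-difluorophenyl in place of (ethoxycarbonyl)methyl on an aromatic nitrogen. For the measured compounds named here, no measured step reads on this change, so no shift beyond the scatter is expected. Compound 4 is estimated at 25000 nM, between 12000 nM and 60000 nM. The step that the limit leaves unreadable from compound 3 to compound 4 is expected to be flat.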

Compound 4, half-maximal cytotoxic concentration: > 20000 nM
Compound 4 was reported as a limit; the forecaster's own chance of this, stated with the estimate: 80%; the middle value is on the limit's open side.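

No step to compound 4 from compound 1, compound 2 or compound 3 can be read, as all of these compounds stop at the same limit: the limit of > 20000 nM in this assay, at which 4 of the 4 values shown sit. The compounds shown leave open whether any of these changes alters toxicity in this assay at all.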